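This account rests on a few compounds, and the source may have more. Where it says the series, first, only, none or still open, it means among the compounds named here.

Values in a functional assay (trachea) with Cavia porcellus as the target; on this read-out lower numbers stand for stronger inhibition and higher numbers for weaker inhibition:
- compound 1 `CCn1nc(-c2cccnc2)c2ccccc2c1=O`: 1320 nM
- compound 2 `CCCCn1nc(-c2cccnc2)c2ccccc2c1=O`: 2290 nM
- compound 3 `CCCCCCCCn1nc(-c2cccnc2)c2ccccc2c1=O`: 21900 nM

In this assay, compound 3 has the highest number of the three and is the weakest. The change to compound 4 `COCCn1nc(-c2cccnc2)c2ccccc2c1=O` is methoxy in place of hexyl on a saturated chain carbon, two bonds along the chain from an aromatic nitrogen. For the measured compounds named here, the steps that bear on it are a 17-fold higher number from compound 1 to compound 3 (1.22 log units; beyond the scatter) and a 9.6-fold higher number from compound 2 to compound 3 (0.98 log units; beyond the scatter), both beyond the scatter, while a 1.7-fold higher number from compound 1 to compound 2 (0.24 log units; within the scatter) stays within it. Going by the values given here, no measured compound carries methoxy, so this rests on the chain steps alone. A large move to a lower number is expected, back towards the level of compound 1 and compound 2. The estimated step is an 11-fold lower number from compound 3 to compound 4 (1.04 log units; beyond the scatter). For compound 4 the estimate is 2000 nM, with an expected range of 600 nM to 7000 nM.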

Compound 4, half-maximal inhibitory concentration: 9330 nM
For compound 4 the middle estimate is 4.7-fold (0.67 log units) below the measured one, and the stated range ends below it.
By their numbers in this assay, from the lowest: compounds 1 and 2 (each within the scatter of the next); then compound 4; then compound 3.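

In this assay, methoxy in place of hexyl recovers only part of the ground lost with the octyl chain (a 2.3-fold lower number from compound 3 to compound 4 (0.37 log units; beyond the scatter)). The same methoxy stands clearly worse than ethyl (a 4.1-fold higher number from compound 2 to compound 4 (0.61 log units; beyond the scatter)) and hydrogen (a 7.1-fold higher number from compound 1 to compound 4 (0.85 log units; beyond the scatter)) at this place, so a short chain ending in methoxy does not match the short alkyl chains of compound 1 and compound 2. Nothing at hand explains this gap. Open, on these data alone, is whether a hydroxy or an amine at the chain end would return to the level of the alkyl chains. Also open, as far as these compounds go, is how a longer chain ending in methoxy would compare with compound 4.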